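Compound 3 to compound 4: methoxy gives way to 2-hydroxyethyl

A few compounds are considered here, and "the series" means these few. Any claim that something is new, unique, unknown or untested is made for them only; others in the source may bear on it.

In an ADME assay on L1210/0 cells (Mus musculus) for cytotoxicity, with a stated time of 48 h (a lower number here means a stronger inhibitor, a higher number a weaker inhibitor), compound 1 `O=c1[nH]c(=O)n([C@H]2C[C@H](O)[C@@H](CO)O2)cc1[N+](=O)[O-]` gives 130 nM. Compound 2 `N#Cc1cn([C@H]2C[C@H](O)[C@@H](CO)O2)c(=O)[nH]c1=O` gives only a limit, > 200000 nM. Compound 3 `COCC#Cc1cn([C@H]2C[C@H](O)[C@@H](CO)O2)c(=O)[nH]c1=O` also gives only a limit, > 200000 nM. Compound 3 therefore stands at the limit of > 200000 nM in this assay, at which 2 of the 3 values shown sit, with no actual number to its name.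

Compound 4 `O=c1[nH]c(=O)n([C@H]2C[C@H](O)[C@@H](CO)O2)cc1C#CCCCO` keeps the shared core and changes only the end of the chain: 2-hydroxyethyl in place of methoxy on a saturated chain carbon bound to a triple-bonded carbon. In words, this is 2-hydroxyethyl in place of methoxy on a saturated chain carbon bound to a triple-bonded carbon, turning 3-methoxyprop-1-yn-1-yl into 5-hydroxypent-1-yn-1-yl.

Among the measured compounds shown here, no measured step makes this exact change, so the evidence is indirect. Putting 3-methoxyprop-1-yn-1-yl in place of nitro gave an at least 1500-fold higher number from compound 1 to compound 3 (3.18 log units; beyond the scatter), a large loss, and cyano in place of nitro gave an at least 1500-fold higher number from compound 1 to compound 2 (3.18 log units; beyond the scatter), equally large. Exchanging those two groups gave a step that the two limits leave unreadable from compound 2 to compound 3, which says nothing about size.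

Compound 4 has no nitro either, and it keeps a triple-bonded chain, so the loss seen in an at least 1500-fold higher number from compound 1 to compound 3 (3.18 log units; beyond the scatter) is expected to persist. The expected result is a number no higher from compound 3 to compound 4 (the limit leaves the size open), meaning no step beyond the scatter. For compound 4 the estimated value is 200000 nM, with an expected range from 70000 nM to 400000 nM.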

Compound 4, half-maximal inhibitory concentration: > 200000 nM
Compound 4: a limit, no number; the forecaster's own chance of this, stated with the estimate: 70%; the middle value lies on the limit itself.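

In this assay, compound 4 gives only a limit, > 200000 nM, and not a number. Among the compounds shown here, the one step that can be read is an at least 1500-fold higher number from compound 1 to compound 4 (3.18 log units; beyond the scatter), so a hydroxy-bearing chain, 5-hydroxypent-1-yn-1-yl, in place of nitro ends at the same limit as 3-methoxyprop-1-yn-1-yl and cyano did. For the compounds shown here, the steps from compound 2 and from compound 3 to compound 4 cannot be read, as both ends of each are limits, and compound 1 remains the only compound here with an actual number: the limit of > 200000 nM in this assay, at which 3 of the 4 values shown sit.

Going by these compounds, how far compound 2, compound 3 and compound 4 each lie past that limit stays open, and so does whether changing the end of the chain has any effect at this position. Also open, on these data alone, is whether an amine or a carboxylic acid at the end of the chain, or an amino group in place of nitro on the shared core, would give a number that can be read at all.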